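Amine-bearing series: swapping fluoro for ethyl on compound 3

The compounds below may be only part of what the source reports. "The series", "measured", "known", "first", "only" and "open" are said of these compounds alone.

Of the compounds shown here, three sharing one core have been measured in a functional assay on FM3A cells (Mus musculus) for inhibition, read by cell counting, with a stated time of 2 days; a lower number here means a stronger inhibitor, a higher number a weaker inhibitor. Compound 1 `COc1ccc(-c2nn3cc(-c4cccc(N)c4)nc3s2)cc1OC` gives 13000 nM. Compound 2 `C=C(Br)C(=O)Nc1cccc(-c2cn3nc(Cc4cccc(OC)c4)sc3n2)c1` gives 1100 nM. Compound 3 `Nc1cccc(-c2cn3nc(-c4ccc(F)cc4)sc3n2)c1` gives 33000 nM, the highest of the three numbers; compound 1 sits nearest, with a lower number beyond the scatter, and compound 2 sits furthest, also well beyond the scatter. Among the compounds with values here, no two of the measured compounds differ in one place only, so no single-point step is available.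

Compound 4 `CCc1ccc(-c2nn3cc(-c4cccc(N)c4)nc3s2)cc1` is not yet measured. Relative to compound 3 it carries the change (ethyl in place of fluoro on an aromatic carbon). Nothing measured here isolates this kind of exchange, so the direction of the step is open. A small step is expected, in either direction, most likely none beyond the scatter; the step from compound 3 to compound 4 is estimated as a 1.2-fold lower number from compound 3 to compound 4 (0.07 log units; within the scatter). For compound 4 in this assay the estimated value is 28000 nM, with a range from 9000 nM to 90000 nM.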

Compound 4, half-maximal inhibitory concentration: 8200 nM
Compound 4: the middle estimate sits 3.4-fold (0.53 log units) above what was measured; measured number outside the range, below it.
By their numbers in this assay, from the lowest: compound 2; then compounds 4 and 1 (each within the scatter of the next); then compound 3.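

Ethyl in place of fluoro, on an aromatic carbon para to a large group, gives a 4.0-fold lower number from compound 3 to compound 4 (0.60 log units; beyond the scatter) in this assay. Within the data shown here, this is the first step that changes one place only, and it shows that the group held at this position can move the number beyond the scatter, with ethyl on the lower side of fluoro. A single pair gives a direction for these two groups only, not a trend, and no measurement at hand gives a reason for the step.

Open, on these data alone, is whether a longer chain such as propyl, or a methoxy group, an amine or a carboxylic acid at this position would lower the number further or raise it again. Also open, as far as these compounds go, is whether the same exchange gives a step of like size when the amine of compound 3 is replaced by the amide found in compound 2.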